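A few compounds are considered here, and "the series" means these few. Any claim that something is new, unique, unknown or untested is made for them only; others in the source may bear on it.

Compound 1, `CCCC(=O)N1c2ccccc2CCC1C(=O)Nc1ccccc1C(F)(F)F`: in a functional assay on MDA-MB-231 cells (Homo sapiens) for cytotoxicity, read by sulforhodamine B assay, with a stated time of 72 h (on this read-out lower numbers stand for stronger inhibition of growth and higher numbers for weaker inhibition of growth), compound 1 gives only a limit, > 70000 nM.
Compound 2, `O=C(Nc1ccc(O)cc1)C1CCc2ccccc2N1`: in this assay compound 2 gives only a limit, > 100000 nM.
Compound 3, `COc1ccc(NC(=O)C2CCc3ccccc3N2)cc1`: in this assay compound 3 gives 51400 nM.

Compound 1 therefore stands at a limit of the assay, not at a number, and the same is true of compound 2 the limit of > 70000 nM in this assay, at which 1 of the 3 values shown sits (the limit of > 100000 nM in this assay, at which 1 of the 3 values shown sits). Going by the values given here, the only measured step runs from compound 2 to compound 3, an at least 1.9-fold lower number from compound 2 to compound 3 (0.28 log units; that floor lies within the scatter), a methyl in place of hydrogen on an oxygen on an aromatic ring; since it starts from a limit, its size is itself only a floor.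

Compound 4, `O=C(Nc1ccccc1C(F)(F)F)C1CCc2ccccc2N1C(=O)c1ccccc1`, differs from compound 1 at the acyl group on the ring nitrogen of the shared core: phenyl in place of propyl on a carbonyl carbon, or, cut one bond further out, propylcarbonyl to benzoyl. Among the compounds with values here, no measured step touches this acyl group, so nothing here speaks for a change beyond the scatter in either direction. The expectation for compound 4 in this assay is therefore a step that the limit leaves unreadable from compound 1 to compound 4 that stays within the scatter. Compound 4 is thus estimated at 80000 nM, within a range from 20000 nM to 300000 nM, most likely again reported as a limit.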

Compound 4, concentration for 50% growth inhibition: 5290 nM
The estimate for compound 4 lay 15-fold (1.18 log units) above the measured number; measured number outside the range, below it.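

Putting phenyl in place of propyl on a carbonyl carbon whose other neighbours are an amide-type nitrogen in a ring gives an at least 13-fold lower number from compound 1 to compound 4 (1.12 log units; beyond the scatter) in this assay. This is the first step shown that lies beyond the scatter, and it shows that growth inhibition in these cells responds to what is carried on this carbonyl, which the earlier compounds could not show because none of their steps touched this place. The true size of the step may be larger still, and it can be read only as a floor because compound 1 stands at a limit and not at a number: the limit of > 70000 nM in this assay, at which 1 of the 4 values shown sits.

This single pair cannot separate the aromatic ring from the larger count of carbon atoms, since phenyl brings both at once, so a cyclohexyl group, with a ring of carbon that is not aromatic, or a longer chain such as hexyl would be needed to tell them apart. As far as these compounds go, it also remains open whether a pyridine ring would serve in place of phenyl, and whether benzoyl would give a step of similar size on a different amide side of the shared core.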